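Swapping a dichloropyridine for a dimethylpyrazole

A few compounds are considered here, and "the series" means these few. Any claim that something is new, unique, unknown or untested is made for them only; others in the source may bear on it.

Of the compounds shown here, three sharing one core have been tested in a functional assay on Jurkat cells for inhibition of nuclear factor NF-kappa-B complex (Homo sapiens); on this read-out higher numbers stand for weaker inhibition and lower numbers for stronger inhibition. Compound 1 `CCOC(=O)c1cnc(C)nc1NN1C(=O)C=C(C)C1=O` gives 16000 nM. Compound 2 `CCOC(=O)c1cnc(-c2ccncc2)nc1NN1C(=O)C=C(C)C1=O` gives 6000 nM, and compound 3 `CCOC(=O)c1cnc(-c2cc(Cl)nc(Cl)c2)nc1NN1C(=O)C=C(C)C1=O` gives 2000 nM, the lowest of the three numbers. The moves that set them apart are a 2.7-fold lower number from compound 1 to compound 2 (0.43 log units; beyond the scatter), an 8.0-fold lower number from compound 1 to compound 3 (0.90 log units; beyond the scatter) and a 3.0-fold lower number from compound 2 to compound 3 (0.48 log units; beyond the scatter).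

Compound 4 `CCOC(=O)c1cnc(-n2nc(C)cc2C)nc1NN1C(=O)C=C(C)C1=O` is not yet measured. The change from compound 3 is 3,5-dimethyl-1H-pyrazol-1-yl in place of 2,6-dichloropyridin-4-yl on an aromatic carbon. Within the data shown here, no measured step exchanges one aromatic ring for another of a different kind, so the guides are indirect: in a 2.7-fold lower number from compound 1 to compound 2 (0.43 log units; beyond the scatter) an aromatic ring in place of methyl lowered the number, and in a 3.0-fold lower number from compound 2 to compound 3 (0.48 log units; beyond the scatter) the dichlorinated ring in place of the plain one lowered it further. Compound 4 keeps an aromatic ring but has no chlorines, so a higher number than that of compound 3 is expected. The expected step is a 2.5-fold higher number from compound 3 to compound 4 (0.40 log units; beyond the scatter). Compound 4 is estimated at 5000 nM, with a likely range from 1500 nM to 16000 nM.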

Compound 4, half-maximal inhibitory concentration: 10000 nM
The estimate for compound 4 lay 2.0-fold (0.30 log units) below the measured number; measured number inside the range.
By their numbers in this assay, from the lowest: compound 3; then compounds 2, 4 and 1 (each within the scatter of the next, the first and the last beyond it).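

In this assay the swap gives a 5.0-fold higher number from compound 3 to compound 4 (0.70 log units; beyond the scatter) and so shows that not every aromatic ring on this aromatic carbon between two ring nitrogen atoms matches the 2,6-dichloropyridin-4-yl group. The 3,5-dimethyl-1H-pyrazol-1-yl group cannot be told apart from pyridin-4-yl, with a 1.7-fold higher number from compound 2 to compound 4 (0.22 log units; within the scatter), or from plain methyl, with a 1.6-fold lower number from compound 1 to compound 4 (0.20 log units; within the scatter), although those two groups do differ from each other beyond the scatter. Nothing measured here gives a reason for these steps.

This swap changes ring size, ring nitrogen count, chlorine content and methyl groups all at once, and the compounds shown cannot separate these changes. Also open, going by these compounds, is how a pyrazol-1-yl ring without methyl groups, a 3,5-dichlorophenyl ring or an amine such as morpholine would read at this position.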